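The source may report more compounds than this note shows. Statements on the series, on what has been measured and on what is new or still open speak of the compounds shown alone.

Measured so far:
compound 1, `O=C(CCCCCc1ccccc1)c1nc2c(F)cccc2o1` — 117 nM
compound 2, `O=C(CCCCCCc1ccccc1)c1nc(-c2ccco2)no1` — 933 nM
compound 3, `O=C(CCc1ccccc1)c1nc2ncccc2o1` — 18200 nM

In an assay on HEK-293T cells for inhibition of diacylglycerol lipase-alpha (Homo sapiens), read by colorimetric assay (a lower number here means a stronger inhibitor, a higher number a weaker inhibitor), compound 3 gives 18200 nM, the highest of the three numbers and beyond the scatter of both others. Compound 2 gives 933 nM and compound 1 gives 117 nM, so compound 3 stands as the weakest inhibitor of the set, with compound 1 at the opposite end.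

Compound 4, `CCCCCC(=O)c1nc2ncccc2o1`, has not yet been measured in this assay. It differs from compound 3 in one place: propyl in place of phenyl on a saturated chain carbon, two bonds along the chain from a carbonyl carbon. Within the data shown here, no pair of measured compounds shows this exact change, so its size can only be guessed. The two stronger compounds keep their phenyl on a longer chain; the data give no measured case of a chain without any ring. Compound 4 is expected to remain a weak inhibitor, with a step no larger than the scatter and, if anything, toward a higher number, so a 1.6-fold higher number from compound 3 to compound 4 (0.22 log units; within the scatter) is the expected shift. On that basis compound 4 is estimated at 30000 nM, within a range of 8000 nM to 100000 nM.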

Compound 4, half-maximal inhibitory concentration: > 10000 nM
Compound 4 was reported as a limit; the forecaster's own chance of this, stated with the estimate: 25%; the middle value lies beyond the limit too.
By their numbers in this assay, from the lowest: compound 1; then compound 2; then compound 3.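

In this assay compound 4 gives > 10000 nM, which is a limit and not a number. The change between compound 3 and compound 4 therefore cannot be read as a step: the limit of > 10000 nM in this assay, at which 1 of the 4 values shown sits.

The compounds shown leave open how strongly compound 4 actually inhibits, and so whether replacing phenyl with propyl changes the number at all.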